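The source may report more compounds than this note shows. Statements on the series, on what has been measured and on what is new or still open speak of the compounds shown alone.

Measured in a functional assay on RS4-11 cells (Homo sapiens) for inhibition, read by CCK-8 assay, with a stated time of 48 h, tested at 20 uM; on this read-out lower numbers stand for less inhibition of growth and higher numbers for more inhibition of growth at the one concentration tested:
- compound 1 `N#C/C(=C\c1ccccc1OS(=O)(=O)c1ccc([N+](=O)[O-])cc1)C(=O)Nc1nnc(-c2cccs2)s1` gives 40%
- compound 2 `COc1ccc(Cc2nnc(NC(=O)/C(C#N)=C/c3ccccc3OS(=O)(=O)c3ccc(C)cc3)s2)cc1` gives 70%
- compound 3 `Cc1ccc(S(=O)(=O)Oc2ccccc2/C=C(\C#N)C(=O)Nc2nnc(Cc3cccc4ccccc34)s2)cc1` gives 73%

In this series, compound 3 at 73% sits level with compound 2 at 70%, within the scatter. Compound 1 at 40% lies beyond the scatter from compound 3. The next compound, compound 4 `N#C/C(=C\c1ccccc1OS(=O)(=O)c1ccc([N+](=O)[O-])cc1)C(=O)Nc1nnc(Cc2cccc3ccccc23)s1`, keeps the rest of compound 3 but has nitro in place of methyl on an aromatic carbon, para to a large group (nitro in place of methyl on an aromatic carbon).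

Going by the values given here, no measured pair isolates this change. Among the compounds with values here, the one measured step, a number 3 percentage points higher from compound 2 to compound 3 (within the scatter), concerns a different group and is small. Compound 4 shares its 4-nitrophenyl sulfonyl group with compound 1, which shows 40%, but compound 1 also differs from compound 3 in a second place, so this value gives only a loose hint. A moderate fall in this assay is therefore expected, though one within the scatter cannot be excluded. The expected change is a number 15 percentage points lower from compound 3 to compound 4 (beyond the scatter). Compound 4 is estimated at 58%, with an expected range from 36% to 80%.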

Compound 4, percent growth inhibition at one concentration: 58%
The estimate for compound 4 equals the measured number at the digits printed, within the range that was stated.
By their numbers in this assay, from the lowest: compound 1; then compound 4; then compounds 2 and 3 (each within the scatter of the next).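

In this assay, going by these compounds alone, the change from 4-methylphenyl to 4-nitrophenyl gives the first direct reading at this position, para to a large group: nitro in place of methyl leaves the number lower (a number 15 percentage points lower from compound 3 to compound 4 (beyond the scatter)), so this position is not indifferent to the change. With the (4-nitrophenyl)sulfonyl group held fixed, the other end of the molecule also matters: (naphthalen-1-yl)methyl in place of thiophen-2-yl raises the number (a number 18 percentage points higher from compound 1 to compound 4 (beyond the scatter)), and both steps lie beyond the scatter. No measured property is available here to account for either step.

The compounds shown leave open how an amine or a carboxylic acid would behave at this same position. They also leave open whether nitro in place of methyl would give a similar step with the 4-methoxyphenyl group at the other end.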